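The source may report more compounds than this note shows. Statements on the series, on what has been measured and on what is new or still open speak of the compounds shown alone.

- Compound 1 `CC(=O)OC/C1=C/C[C@](C)(CCC=C(C)C)/C=C/[C@@H](OC(=O)C=C(C)C)[C@](C)(O)/C=C/C1=O`: 2950 nM
- Compound 2 `COCOC/C1=C/C[C@](C)(CCC=C(C)C)/C=C/[C@@H](OC(=O)C=C(C)C)[C@](C)(O)/C=C/C1=O`: 2840 nM
- Compound 3 `CC(C)=CCC[C@]1(C)/C=C/[C@@H](OC(=O)C=C(C)C)[C@](C)(O)/C=C/C(=O)/C(Cn2cc(CO)nn2)=C\C1`: 3200 nM

In a functional assay on HL-60 cells (Homo sapiens) for antiproliferative activity, read by MTT assay, with a stated time of 48 h (a higher number here means a weaker inhibitor, a lower number a stronger inhibitor), compound 3 gives 3200 nM, level with the other two within the scatter. Compound 4 `CC(C)=CCC[C@]1(C)/C=C/[C@@H](OC(=O)C=C(C)C)[C@](C)(O)/C=C/C(=O)/C(C(=O)N2CCCC2)=C\C1` brings one change: (pyrrolidin-1-yl)carbonyl in place of (4-(hydroxymethyl)-1H-1,2,3-triazol-1-yl)methyl on a double-bonded ring carbon. The closest evidence comes from earlier swaps of the group on the saturated chain carbon bound to the double-bonded ring carbon: a 1.1-fold higher number from compound 1 to compound 3 (0.04 log units; within the scatter), a 1.1-fold higher number from compound 2 to compound 3 (0.05 log units; within the scatter) and a 1.0-fold lower number from compound 1 to compound 2 (0.02 log units; within the scatter). All three were small, within the scatter. For the measured compounds named here, compound 4 loses that saturated chain carbon, and no measured compound shows this kind of change, so the evidence is only partial. No step beyond the scatter is therefore expected, though the range is left wider on the weaker side. The expected step is a 1.1-fold higher number from compound 3 to compound 4 (0.04 log units; within the scatter). For compound 4 the estimated value is 3500 nM, with an expected range of 1500 nM to 9000 nM.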

Compound 4, half-maximal inhibitory concentration: 12300 nM
Estimate against measurement, compound 4: 3.5-fold (0.55 log units) below; the whole stated range lies below it.
By their numbers in this assay, from the lowest: compounds 2, 1 and 3 (each within the scatter of the next); then compound 4.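

Earlier swaps on the saturated chain carbon left this assay flat, but this position does respond to change: with (pyrrolidin-1-yl)carbonyl on the double-bonded ring carbon, all three steps go beyond the scatter toward a weaker inhibitor (a 3.8-fold higher number from compound 3 to compound 4 (0.58 log units; beyond the scatter); a 4.3-fold higher number from compound 2 to compound 4 (0.64 log units; beyond the scatter); a 4.2-fold higher number from compound 1 to compound 4 (0.62 log units; beyond the scatter)). Nothing measured here accounts for this loss. On these data alone, compound 4 changes the linking carbon and the ring together, so it remains open which of them matters. The amine (pyrrolidin-1-yl)methyl, which keeps the saturated chain carbon, would separate the two.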